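Amide nitrogen substituents on the shared core

The source may hold more compounds than are shown below. What is called first, only, known or untested is meant among the compounds shown, and "the series" means these compounds.

For the measured compounds named here, compound 2 `CCn1c(C(=O)NC2(CO)CC2)ccc1C(CC)(CC)c1ccc(OCS(=O)(=O)c2ccccc2)c(C)c1` carries a 1-(hydroxymethyl)cyclopropyl on the amide-type nitrogen of the shared core, and in a functional assay on BXPC-3 cells (Homo sapiens) for antiproliferative activity, read by MTT assay, with a stated time of 24 h (a higher number here means a weaker inhibitor, a lower number a stronger inhibitor), compound 2 gives 45400 nM, the highest of the three numbers measured so far. Compound 1 `CCn1c(C(=O)N[C@@H](C)C(=O)OC)ccc1C(CC)(CC)c1ccc(OCS(=O)(=O)c2ccccc2)c(C)c1` gives 17900 nM in this assay, and compound 3 `CCn1c(C(=O)N[C@@H](C)C(=O)O)ccc1C(CC)(CC)c1ccc(OCS(=O)(=O)c2ccccc2)c(C)c1` gives 20800 nM. The steps leading away from compound 2 are a 2.2-fold lower number from compound 2 to compound 3 (0.34 log units; beyond the scatter) and, read the other way, a 2.5-fold higher number from compound 1 to compound 2 (0.40 log units; beyond the scatter); the remaining step, a 1.2-fold higher number from compound 1 to compound 3 (0.07 log units; within the scatter), stays within the scatter.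

Compound 4 `CCn1c(C(=O)N[C@@H](CCC(=O)O)C(=O)O)ccc1C(CC)(CC)c1ccc(OCS(=O)(=O)c2ccccc2)c(C)c1` is the next member to be measured. The change from compound 2 is 1,3-dicarboxypropyl in place of 1-(hydroxymethyl)cyclopropyl on an amide-type nitrogen. The step that bears most directly on it is the one in which 1-carboxyethyl replaces the same group, a 2.2-fold lower number from compound 2 to compound 3 (0.34 log units; beyond the scatter); the exchange of hydrogen for methyl on an oxygen next to a carbonyl group, a 1.2-fold higher number from compound 1 to compound 3 (0.07 log units; within the scatter), shows that a carboxy group at this place changes little. Since 1,3-dicarboxypropyl again places a carboxy-bearing chain on the amide-type nitrogen, a modest fall is expected, and for compound 4 the estimated step is a 2.1-fold lower number from compound 2 to compound 4 (0.31 log units; beyond the scatter). For compound 4 the expected number in this assay is 22000 nM, with a range from 8000 nM to 60000 nM.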

Compound 4, half-maximal inhibitory concentration: > 50000 nM
Compound 4 was reported as a limit; the forecaster's own chance of this, stated with the estimate: 5%; middle value at least 2.2-fold (0.35 log units) away from the limit.
By their numbers in this assay, from the lowest: compounds 1 and 3 (each within the scatter of the next); then compound 2. At a limit, above all of these: compound 4.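

Compound 4 is reported in this assay only as a limit, not as a number: the limit of > 50000 nM in this assay, at which 1 of the 4 values shown sits.

Adding carboxymethyl to the saturated chain is the cleanest reading of the new result, with an at least 2.4-fold higher number from compound 3 to compound 4 (0.38 log units; beyond the scatter) as the step, and the exchange of 1-(methoxycarbonyl)ethyl for 1,3-dicarboxypropyl gives an at least 2.7-fold higher number from compound 1 to compound 4 (0.44 log units; beyond the scatter) as the step, so a carboxy-bearing chain on the amide-type nitrogen is not enough to hold the number near that of the 1-carboxyethyl compound, a point the earlier ester-to-acid pair could not show. The lower number that came with 1-carboxyethyl in place of 1-(hydroxymethyl)cyclopropyl does not carry over to 1,3-dicarboxypropyl, although an at least 1.1-fold higher number from compound 2 to compound 4 (0.04 log units; that floor lies within the scatter) is only a floor within the scatter and leaves the order of these two compounds unsettled.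

On these data alone, whether the second carboxylic acid or the longer chain itself goes with the higher number stays open, and a chain of the same length ending in a methyl ester, a primary amide or an amine would separate the two. As far as these compounds go, the true value of compound 4 also stays open, and with it the size of all three steps.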